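Thiazolyl for pyrimidinyl on the core of compound 2

The compounds below may be only part of what the source reports. "The series", "measured", "known", "first", "only" and "open" are said of these compounds alone.

Going by the values given here, compound 2 `Cc1ccc(-c2ncccn2)c(C(=O)N2CC3(CC3)C[C@H]2CNc2ccc(C(F)(F)F)cn2)n1` sits in the middle of the three measured members. In a functional assay on CHO cells for antagonist activity at Orexin/Hypocretin receptor type 1 (Homo sapiens), read by FLIPR and calcium flux (a lower number here means a less potent compound, a higher number a more potent compound, by a factor of ten per unit of this negative logarithm), compound 2 gives 8.4. Compound 1 `Cc1cnn(-c2ccc(C)nc2C(=O)N2CC3(CC3)C[C@H]2CNc2ccc(C(F)(F)F)cn2)c1` gives 8.9 and compound 3 `O=C(c1ncccc1-c1ncccn1)N1CC2(CC2)C[C@H]1CNc1ccc(C(F)(F)F)cn1` gives 7.7. The step of a number 0.50 log units lower from compound 1 to compound 2 (beyond the scatter) comes with pyrimidin-2-yl in place of 4-methyl-1H-pyrazol-1-yl on an aromatic carbon, and the step of a number 0.70 log units lower from compound 2 to compound 3 (beyond the scatter) comes with hydrogen in place of methyl on an aromatic carbon.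

Compound 4 `Cc1ccc(-c2nccs2)c(C(=O)N2CC3(CC3)C[C@H]2CNc2ccc(C(F)(F)F)cn2)n1` differs from compound 2 in one place: 1,3-thiazol-2-yl in place of pyrimidin-2-yl on an aromatic carbon. Of the measured steps, only the exchange of the aromatic group on that carbon, from compound 1 to compound 2, bears on this change; it was modest, and the methyl step from compound 2 to compound 3 concerns a different position. Among the compounds with values here, no measured pair swaps a six-membered for a five-membered aromatic group, so the direction is open; a step of similar modest size, in either direction or none beyond the scatter, is expected here. The estimated step is no change at the digits printed from compound 2 to compound 4 (within the scatter), and compound 4 is expected to give 8.4 in this assay, between 7.8 and 9.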

Compound 4, negative logarithm of the antagonist equilibrium constant: 8.6
Compound 4: middle estimate off by 0.20 log units, on the low side, within the range that was stated.
By their numbers in this assay, from the lowest: compound 3; then compounds 2, 4 and 1 (each within the scatter of the next, the first and the last beyond it).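

In this assay, the move to 1,3-thiazol-2-yl on this aromatic carbon, ortho to a large group, gives a number 0.20 log units higher from compound 2 to compound 4 (within the scatter), and against the 4-methyl-1H-pyrazol-1-yl group it gives a number 0.30 log units lower from compound 1 to compound 4 (within the scatter). The step from compound 1 to compound 2 alone could have been read as a difference between a five-membered and a six-membered aromatic ring, but the five-membered ring of compound 4 lies within the scatter of both compounds, so ring size does not separate them here. Nothing at hand explains either step.

On these data alone, whether an open-chain group on this carbon, such as a dimethylamino group or a carboxylic acid, would be tolerated remains open. So does whether the 1,3-thiazol-2-yl group holds its value without the methyl group absent from compound 3.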